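Thiazole amides as free fatty acid receptor 2 agonists

The source may hold more compounds than are shown below. What is called first, only, known or untested is meant among the compounds shown, and "the series" means these compounds.

Measured compounds:
compound 1, `CC(C)[C@H](C(=O)Nc1ccccc1)c1ccc(Cl)cc1`: < 30%
compound 2, `CC(C)C(C(=O)Nc1cnccn1)c1ccc(Cl)cc1`: 115%
compound 3, `CC(C)C(C(=O)Nc1nc(-c2cccnc2)cs1)c1ccc(Cl)cc1`: < 30%

Three amides sharing the core of compound 1 have been measured in a functional assay on CHO cells for agonist activity at Free fatty acid receptor 2 (Homo sapiens), read by cAMP accumulation; on this read-out higher numbers stand for larger maximal responses and lower numbers for smaller maximal responses. In this assay compound 1 reaches only < 30%, which is a limit of the assay and not a number. Compound 2, carrying a pyrazinyl group on the amide nitrogen, gives 115%. Compound 3 gives < 30%, again a limit rather than a number. Compound 1 thus stands at the limit of < 30% in this assay, at which 2 of the 3 values shown sit, alongside compound 3, while compound 2 alone yields a measurable response.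

Compound 4, `CC(C)[C@H](C(=O)Nc1ncc(C#N)s1)c1ccc(Cl)cc1`, is not yet measured in this assay. It differs from compound 1 in one place: 5-cyano-1,3-thiazol-2-yl in place of phenyl on an amide-type nitrogen.

Since compound 1 offers only a limit, the size of the step cannot be computed in advance. Compound 3, with its larger pyridinyl-substituted thiazole, gives < 30%, which is a limit of the assay. Given that compound 2, with a small nitrogen-containing aromatic ring on the amide nitrogen, gives 115%, compound 4 with its compact 5-cyano-1,3-thiazol-2-yl group is expected to show a clear gain beyond the scatter, a step of a number at least 55 percentage points higher from compound 1 to compound 4 (beyond the scatter). Compound 4 is therefore estimated at 85%, within a range from 35% to 120%.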

Compound 4, largest response reached (reported as efficacy), in percent of the reference or control that the assay uses: 105%
Compound 4: middle estimate off by 20 percentage points, on the low side; low and high end bracket the measured number.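

In this assay, among these compounds, 5-cyano-1,3-thiazol-2-yl in place of phenyl on the amide-type nitrogen gives a number at least 75 percentage points higher from compound 1 to compound 4 (beyond the scatter), and this large change is the first that can be read at this position, as no two of the earlier compounds differed in one place only. It shows that a single exchange at this nitrogen, with the rest of the core of compound 1 unchanged, is enough to turn a response that stayed at a limit of the assay into a measurable one. The step has only a lower bound and its full size cannot be read, because the value of compound 1 is a limit of the assay and not a number: the limit of < 30% in this assay, at which 2 of the 4 values shown sit.

The compounds shown leave open whether the gain belongs to the five-membered ring or to the nitrile, since the two enter together and an unsubstituted 1,3-thiazol-2-yl group does not stand among them. They also leave open how a carboxamide or a chlorine atom in place of the nitrile would fare in this assay.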